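A few compounds are considered here, and "the series" means these few. Any claim that something is new, unique, unknown or untested is made for them only; others in the source may bear on it.

Working notes on the series. Going by the values given here, the three measured members share one core and differ only in the substituent on the phenyl attached to the sulfonyl sulfur. Compound 1 `CC1CCN(c2c(S(=O)(=O)c3ccc(Cl)cc3)cnc3cc(Cl)ccc23)CC1` gives 91% in an assay on isolated protein for displacement of a labelled ligand from metabotropic glutamate receptor 5 (Homo sapiens), with a stated time of 60 min, tested at 1 uM; a lower number here means less inhibition, a higher number more inhibition at the concentration tested (going by the name of the read-out). Compound 2 `CC1CCN(c2c(S(=O)(=O)c3ccc(F)cc3)cnc3cc(Cl)ccc23)CC1` gives 91% in this assay. Compound 3 `Cc1ccc(S(=O)(=O)c2cnc3cc(Cl)ccc3c2N2CCC(C)CC2)cc1` gives 94% in this assay. Compound 3 holds the highest of the three numbers, but its gap to compound 1, a number 3 percentage points higher from compound 1 to compound 3 (within the scatter), and its gap to compound 2, a number 3 percentage points higher from compound 2 to compound 3 (within the scatter), both lie within the scatter, so no order among the three can be read from these numbers. The step of no change at the digits printed from compound 1 to compound 2 (within the scatter) points the same way: chloro, fluoro and methyl at this phenyl are indistinguishable here.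

Compound 4 `CC1CCN(c2c(S(=O)(=O)c3ccc(Cl)c(Cl)c3)cnc3cc(Cl)ccc23)CC1` is not yet measured. Its change from compound 3: 3,4-dichlorophenyl in place of 4-methylphenyl on a sulfonyl sulfur. Among the compounds with values here, the steps that bear on it are those in which the same phenyl was varied, a number 3 percentage points higher from compound 1 to compound 3 (within the scatter) and a number 3 percentage points higher from compound 2 to compound 3 (within the scatter), and both were within the scatter. Within the data shown here, no measured compound covers a 3,4-dichlorophenyl at this position, so the expectation rests on the flatness of those steps alone. The step expected in this assay is therefore a number 3 percentage points lower from compound 3 to compound 4 (within the scatter), none beyond the scatter. Compound 4 is expected to give 91%, in the range 82% to 98%.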

Compound 4, a percentage reported as inhibition, at one concentration (the size of the read-out at that concentration, not a potency): 89%
For compound 4 the middle estimate is 2 percentage points above the measured one; low and high end bracket the measured number.
By their numbers in this assay, from the lowest: compounds 4, 1, 2 and 3 (each within the scatter of the next).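

Within this assay, the phenyl on the sulfonyl sulfur now carries a second substituent for the first time, and adding chloro to the 4-chlorophenyl of compound 1 gives a number 2 percentage points lower from compound 1 to compound 4 (within the scatter). The exchanges that reach the 3,4-dichlorophenyl from the other two phenyls, a number 5 percentage points lower from compound 3 to compound 4 (within the scatter) and a number 2 percentage points lower from compound 2 to compound 4 (within the scatter), also stay within the scatter, so the flat picture now covers a second substituent as well as single exchanges, and all four compounds remain without an order among them. Nothing available explains why the numbers stay level at this position.

As far as these compounds go, it remains open whether an amine or a carboxylic acid on this phenyl, a longer chain in its place, or a different group on the sulfonyl sulfur altogether would move the number beyond the scatter. Because each compound is represented by inhibition at a single concentration, these numbers also leave open whether the four compounds differ in potency.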